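Trading Ethoxy for Isopropyl on the Thioether Ring

The compounds below may be only part of what the source reports. "The series", "measured", "known", "first", "only" and "open" are said of these compounds alone.

Going by the values given here, in an assay (Rattus norvegicus) for binding affinity to prostacyclin receptor (Homo sapiens), read by radioligand binding (on this read-out higher numbers stand for weaker inhibition and lower numbers for stronger inhibition), compound 2 `CCOc1ccc(Sc2ccc(NC3=NCCN3)cc2)cc1` gives 39.8 nM, the lowest of the two numbers measured so far. Compound 1 `c1ccc(Sc2ccc(NC3=NCCN3)cc2)cc1` gives 794 nM, and the step of a 20-fold lower number from compound 1 to compound 2 (1.30 log units; beyond the scatter) is large. Compound 3 `CC(C)c1ccc(Sc2ccc(NC3=NCCN3)cc2)cc1` carries isopropyl in place of ethoxy on an aromatic carbon. Among the compounds with values here, no measured step exchanges one substituent for another at that carbon; the single known step only shows that adding the ethoxy there matters a great deal, so the expectation here is uncertain. Since the ethoxy is removed and replaced, the estimated step is a 2.5-fold higher number from compound 2 to compound 3 (0.40 log units; beyond the scatter). Compound 3 is thus estimated at 100 nM, with a range from 25 nM to 400 nM.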

Compound 3, inhibition constant: 251 nM
Beside the measured number, compound 3's estimate is 2.5-fold (0.40 log units) below it; the range from low to high includes it.
By their numbers in this assay, from the lowest: compound 2; then compound 3; then compound 1.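

At this carbon, exchanging one substituent for another gives a 6.3-fold higher number from compound 2 to compound 3 (0.80 log units; beyond the scatter), so ethoxy and isopropyl, despite their equal count of heavy atoms, are not interchangeable here. Isopropyl still keeps part of the gain over hydrogen, with a 3.2-fold lower number from compound 1 to compound 3 (0.50 log units; beyond the scatter), which shows that a substituent without oxygen can also lower the number, though less than ethoxy does. Nothing available explains the gap between these two groups. The compounds shown leave open where a straight propyl chain or a methoxy group at this carbon would fall, so the oxygen and the branching cannot yet be told apart.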